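Cytotoxicity notes on a benzimidazolone series

A few compounds are considered here, and "the series" means these few. Any claim that something is new, unique, unknown or untested is made for them only; others in the source may bear on it.

Compound 1 `O=c1[nH]c2ccc(Cl)cc2n1S(=O)(=O)c1c(F)cccc1F` gives 194000 nM in an ADME assay on MT4 cells (Homo sapiens) for cytotoxicity; on this read-out higher numbers stand for lower toxicity in this test and lower numbers for higher toxicity in this test. Compound 3 `Cc1ccc2[nH]c(=O)n(S(=O)(=O)c3c(F)cccc3F)c2c1` differs from it by methyl in place of chloro on an aromatic carbon and gives 2220 nM in this assay, so the step of an 87-fold lower number from compound 1 to compound 3 (1.94 log units; beyond the scatter) is a large drop in the number, that is, a marked gain in toxicity. Compound 2 `Cc1cc(C)cc(Cn2c(=O)[nH]c3ccc(Cl)cc32)c1` carries a different core; the difference between the two cores is not broken down here. In this assay compound 2 gives 8900 nM, which stands between the two sulfonyl compounds and beyond the scatter of each.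

Compound 4 `Cc1cc(C)cc(Cn2c(=O)[nH]c3ccc(C)cc32)c1` is not yet measured. It differs from compound 2 by methyl in place of chloro on an aromatic carbon, the same change that turns compound 1 into compound 3, at a place described in the same words. The expected step of a 3.6-fold lower number from compound 2 to compound 4 (0.55 log units; beyond the scatter) in this assay is smaller than the measured one, since the earlier step rests on a single pair on another core and nothing shows whether the benzyl core responds alike. For compound 4 the estimate in this assay is 2500 nM, with an expected range from 300 nM to 15000 nM.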

Compound 4, half-maximal cytotoxic concentration: 856 nM
Compound 4: the middle estimate sits 2.9-fold (0.47 log units) above what was measured, and the stated range covers the measured number.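

Methyl in place of chloro on an aromatic carbon again lowers the number in this assay (a 10-fold lower number from compound 2 to compound 4 (1.02 log units; beyond the scatter)), so in these two pairs the direction of the change carries from the core of compound 1 to the core of compound 2, with a marked gain in toxicity each time. The size of the step does not carry over, and the two pairs differ clearly: the same change on two cores in this assay, an 87-fold lower number (1.94 log units; beyond the scatter) from compound 1 to compound 3 and a 10-fold lower number (1.02 log units; beyond the scatter) from compound 2 to compound 4, 8.4-fold (0.92 log units) apart, beyond the scatter of two such steps. Among these compounds, with one pair on each core, this shows only that the step depends on its setting in these compounds; it does not show which feature of the two cores sets the size, and it gives no rule for a further core.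

Still open, on these data alone, is whether an amine, a methoxy group or a longer chain at the same aromatic carbon would move the number the same way as methyl. Also open, as far as these compounds go, is whether the change keeps its direction on a third core.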